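Swapping carboxy for acetamido in a cytotoxicity series

The source may report more compounds than this note shows. Statements on the series, on what has been measured and on what is new or still open speak of the compounds shown alone.

Compound 1 `O=C(O)c1ccc(C(=O)/C=C/c2ccc3c(c2)B(O)OC3)cc1`: > 10 ug/mL in an ADME assay on L929 cells (Mus musculus) for cytotoxicity, read by resazurin assay, with a stated time of 72 h; a lower number here means a stronger inhibitor, a higher number a weaker inhibitor
Compound 2 `COc1cccc(C(=O)CCc2ccc3c(c2)B(O)OC3)c1`: > 10 ug/mL in this assay
Compound 3 `COc1cc(C(=O)/C=C/c2ccc3c(c2)B(O)OC3)cc(OC)c1OC`: > 10 ug/mL in this assay

For compound 1 the reported value is a limit of the assay, not a number. For compound 2 the value is likewise a limit. For compound 3 the value is a limit as well. All three therefore sit at the limit of > 10 ug/mL in this assay, at which 3 of the 3 values shown sit, so compound 1 stands together with the other two at the edge of what this assay can resolve, and no one of them can be called more or less toxic than another.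

The next compound, compound 4 `CC(=O)Nc1ccc(C(=O)/C=C/c2ccc3c(c2)B(O)OC3)cc1`, is reached from compound 1 by a single change: acetamido in place of carboxy on an aromatic carbon. Among the measured compounds shown here, no pair of measured compounds differs in just one place, so there is no measured step to lean on. Every measured compound, including compound 2 and compound 3 with quite different substituents, returns only a limit, and nothing in these results points to a shift in either direction. The step from compound 1 to compound 4 is therefore expected to be none beyond the scatter, a step that the limit leaves unreadable from compound 1 to compound 4. In this assay compound 4 is estimated at 15 ug/mL, with a range from 5 ug/mL to 50 ug/mL, most likely reported again only as a limit.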

Compound 4, half-maximal inhibitory concentration: > 10 ug/mL
Compound 4 was reported as a limit (the forecaster's own chance of this, stated with the estimate: 85%); the middle value does not contradict the limit.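

Putting acetamido in place of carboxy gives no step that can be read from compound 1 to compound 4, because both compounds return only a limit rather than a number: the limit of > 10 ug/mL in this assay, at which 4 of the 4 values shown sit.

The compounds shown leave open what actual value any of the four would have in this assay, and so whether this swap changes anything at all.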